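A few compounds are considered here, and "the series" means these few. Any claim that something is new, unique, unknown or untested is made for them only; others in the source may bear on it.

Measured compounds, on a physicochemical assay for solubility, with a stated time of 18 h, at pH 7.4; on this read-out higher numbers stand for higher solubility and lower numbers for lower solubility:

compound 1, `COc1ccccc1Oc1ccc2c(NCCCNCc3ccco3)ccnc2c1` — 14500 nM
compound 2, `COc1cccc(Oc2ccc3c(NCCCNCc4cc(F)ccc4OC)ccnc3c2)c1` — 14500 nM

Compound 2 stands level with compound 1 at the digits given; the two values lie within the scatter of this assay, so nothing separates them and no order between them can be read. Both carry the same core with a phenoxy group on the aromatic carbon and a 3-aminopropyl side chain ending in a benzylic amine; they differ in the substitution of the phenoxy ring and of the benzyl group, yet this assay shows no change at the digits.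

Compound 3, `CCC(CC)c1ccc2c(NCCCNCc3cc(F)ccc3OC)ccnc2c1`, is not yet measured in this assay. It keeps the side chain of compound 2 and differs from it only at the aromatic carbon of the core: pentan-3-yl in place of 3-methoxyphenoxy on an aromatic carbon. Among the measured compounds shown here, no step between measured compounds bears on this change, so the direction of the step in this assay has no precedent here. The expectation is a step that stays within the scatter, with a slight lean upward: the step from compound 2 is estimated as a 1.2-fold higher number from compound 2 to compound 3 (0.09 log units; within the scatter). Compound 3 is accordingly expected to give about 18000 nM in this assay, within a range from 6000 nM to 50000 nM.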

Compound 3, solubility: 4200 nM
Beside the measured number, compound 3's estimate is 4.3-fold (0.63 log units) above it, outside the stated range (below it).
By their numbers in this assay, from the lowest: compound 3; then compounds 1 and 2 (each within the scatter of the next).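

In this assay, the aromatic carbon of the shared core now proves responsive to a single change with the side chain held constant: pentan-3-yl in place of 3-methoxyphenoxy gives a 3.5-fold lower number from compound 2 to compound 3 (0.54 log units; beyond the scatter), a step beyond the scatter. Compound 1 and compound 2 could not show this, as they differ in more than one place and their values stand level, so neither the position nor either substituent could be read on its own. The change swaps a group with a six-membered aromatic ring and hydrogen-bond acceptors for a smaller acyclic group that has neither, and nothing measured here accounts for the step.

On these data alone, it remains open which part of the swap goes with the lower number; an unsubstituted phenoxy, a phenyl and a cyclohexyl group on this aromatic carbon would separate the ring, the oxygen atoms and the ring's aromatic character. Also open, as far as these compounds go, are whether an amine or a carboxylic acid at this carbon would shift the read-out, and whether the step carries over to the side chain of compound 1.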